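Benzimidazole-rhodanine series: benzyl swap and cytotoxicity

The compounds below may be only part of what the source reports. "The series", "measured", "known", "first", "only" and "open" are said of these compounds alone.

Measured compounds:
compound 1, `COc1ccc2c(c1)nc(/C=C1\SC(=S)N(CC(=O)O)C1=O)n2Cc1ccc(C)cc1`, 1790 nM
compound 2, `Cc1ccc(Cn2c(/C=C3\SC(=S)NC3=O)nc3ccccc32)cc1`, 4480 nM
compound 3, `COc1ccc2c(c1)nc(/C=C1\SC(=S)N(CC(=O)O)C1=O)n2Cc1ccccc1F`, 11500 nM

All three were run in a functional assay on Raji cells (Homo sapiens) for cytotoxicity, read by MTT assay, with a stated time of 48 h; on this read-out lower numbers stand for stronger inhibition and higher numbers for weaker inhibition. Compound 1 gives 1790 nM, compound 2 gives 4480 nM, and compound 3 gives 11500 nM. Compound 1 and compound 3 differ in one place: 2-fluorophenyl in place of 4-methylphenyl on a saturated chain carbon bound to an aromatic nitrogen. That change produced a 6.4-fold higher number from compound 1 to compound 3 (0.81 log units; beyond the scatter).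

The core of compound 2 is not the core of compound 1; the difference between the two cores is not broken down here. Compound 2 stands between the other two, with its number higher than that of compound 1 and lower than that of compound 3, both gaps beyond the scatter.

Compound 4, `O=C1NC(=S)S/C1=C\c1nc2ccccc2n1Cc1ccccc1F`, is not yet measured. It differs from compound 2 by 2-fluorophenyl in place of 4-methylphenyl on a saturated chain carbon bound to an aromatic nitrogen, and the place of the change is the same as for the pair compound 1 and compound 3, so it is the same change made on the other core. The step is expected to run in the same direction, though because a 6.4-fold higher number from compound 1 to compound 3 (0.81 log units; beyond the scatter) was measured on a core that compound 4 does not share, a somewhat smaller step is expected, a 4.0-fold higher number from compound 2 to compound 4 (0.60 log units; beyond the scatter). Compound 4 is estimated at 18000 nM in this assay, with a range from 7000 nM to 45000 nM.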

Compound 4, half-maximal inhibitory concentration: 25500 nM
Estimate against measurement, compound 4: 1.4-fold (0.15 log units) below; measured number inside the range.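

In this assay, replacing 4-methylbenzyl with 2-fluorobenzyl on the core of compound 2 gives a 5.7-fold higher number from compound 2 to compound 4 (0.76 log units; beyond the scatter), so the weakening seen on the core of compound 1 recurs on a second core. The two steps agree in direction and size: the same change on two cores in this assay, a 6.4-fold higher number (0.81 log units; beyond the scatter) from compound 1 to compound 3 and a 5.7-fold higher number (0.76 log units; beyond the scatter) from compound 2 to compound 4, 1.1-fold (0.05 log units) apart, within the scatter of two such steps

This shows that the change carried over between these two cores in this cell read-out, but it does not show that it would carry to any further core or to another cell line, and it gives no reason for the step.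

Still open, as far as these compounds go, is whether the step comes from losing the methyl, gaining the fluorine or both, which a plain benzyl group carrying neither substituent would help to separate. Also open, from the compounds shown here alone, is how the methoxy group and the acetic acid chain, present in compound 1 and compound 3 but absent from compound 2 and compound 4, each contribute, and whether a longer carboxylic acid chain or an amine in place of the acid would leave the step unchanged.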